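Fluoro for methyl on the urea aryl ring

The source may report more compounds than this note shows. Statements on the series, on what has been measured and on what is new or still open speak of the compounds shown alone.

Measured so far:
- compound 1, `Cc1ccccc1NC(=O)N[C@H](C)c1ccccc1`: 100%
- compound 2, `Cc1ccccc1NC(=O)N[C@@H](C)c1ccccc1`: 99%
- compound 3, `C[C@H](NC(=O)Nc1ccc(C(C)(C)C)cc1)c1ccccc1`: 88%

In an ADME assay on the whole organism with Oryza sativa as the target, tested at 1 uM (a higher number here means a weaker effect of the compound at the concentration tested, a lower number a stronger effect), compound 1 gives 100%, the highest of the three numbers shown. Compound 2 lies close: the change a number 1 percentage points lower from compound 1 to compound 2 (within the scatter) is within the scatter, which fits (the fact that compounds 1 and 2 differ only in the configuration as drawn), the two compounds sharing all atoms and bonds and differing only in how one stereocentre is drawn. Among the compounds with values here, compound 3 stands lower than compound 1, beyond the scatter, but it differs from compound 1 in more than one place, so no single step is drawn between them.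

Compound 4, `C[C@@H](NC(=O)Nc1ccccc1F)c1ccccc1`, is the next case. Relative to compound 1 the change is fluoro in place of methyl on an aromatic carbon. Within the data shown here, none of the measured steps bears on such an exchange; the only step on record, the one between compound 1 and compound 2, concerns configuration alone and was within the scatter. With nothing in the data pointing to a change in this assay, compound 4 is expected to stay near compound 1, with the step of a number 3 percentage points lower from compound 1 to compound 4 (within the scatter) expected to lie within the scatter. The estimate for compound 4 is 97%, with a range from 85% to 100%.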

Compound 4, a percentage reported as activity, at one concentration (the size of the read-out at that concentration, not a potency): 95%
Estimate against measurement, compound 4: 2 percentage points above; the measured number falls inside the stated range.
By their numbers in this assay, from the lowest: compounds 3, 4, 2 and 1 (each within the scatter of the next, the first and the last beyond it).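

At this position, on an aromatic carbon ortho to a large group, the series now has its first step that exchanges a substituent rather than a configuration. In this assay the exchange of methyl for fluoro gives a number 5 percentage points lower from compound 1 to compound 4 (within the scatter) and so does not separate the two groups at this place. Nothing on record bears on why this step is as small as it is.

The compounds shown leave open whether another group at the same place, such as chloro, methoxy or a carboxylic acid, would move the number in this assay beyond the scatter. They also leave open whether fluoro would give the same number with the stereocentre drawn the other way, as the only pair of mirror-drawn compounds shown carries methyl.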